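A few compounds are considered here, and "the series" means these few. Any claim that something is new, unique, unknown or untested is made for them only; others in the source may bear on it.

Within the data shown here, compound 2 `C=C1C(=O)O[C@@H]2CC(C)=C([C@@H](C)CCCOC(C)=O)[C@@H](OC(=O)c3ccccc3F)[C@H]12` gives 19300 nM in a functional assay on SGC-7901 cells (Homo sapiens) for cytotoxicity, read by sulforhodamine B assay, with a stated time of 72 h (on this read-out lower numbers stand for stronger inhibition and higher numbers for weaker inhibition), the higher of the two numbers in hand, though its nearest neighbour, compound 1 `C=C1C(=O)O[C@@H]2CC(C)=C([C@@H](C)CCCOC(C)=O)[C@@H](OC(=O)CN3CCCC3)[C@H]12` with 18400 nM, sits within the scatter of it, as the single measured step, a 1.0-fold higher number from compound 1 to compound 2 (0.02 log units; within the scatter), shows. Compound 3 `C=C1C(=O)O[C@@H]2CC(C)=C([C@@H](C)CCCOC(C)=O)[C@@H](OC(=O)c3ccc(F)cc3)[C@H]12` differs from compound 2 by 4-fluorophenyl in place of 2-fluorophenyl on a carbonyl carbon. Among the measured compounds shown here, no measured step moves a fluorine around the ring in this way; the only step in hand swaps the whole group on the carbonyl carbon and still stays within the scatter, so no step beyond the scatter is expected in this assay. Compound 3 is therefore estimated at 19000 nM, between 8000 nM and 45000 nM, which means a 1.0-fold lower number from compound 2 to compound 3 (0.01 log units; within the scatter).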

Compound 3, half-maximal inhibitory concentration: 13600 nM
Compound 3: middle estimate off by 1.4-fold (0.15 log units), on the high side, within the range that was stated.
By their numbers in this assay, from the lowest: compounds 3, 1 and 2 (each within the scatter of the next).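

The swap of 2-fluorophenyl for 4-fluorophenyl on this carbonyl carbon gives a 1.4-fold lower number from compound 2 to compound 3 (0.15 log units; within the scatter) and stays within the scatter, so the place of the fluorine on the ring makes no readable difference in this assay here. The swap of (pyrrolidin-1-yl)methyl for 4-fluorophenyl gives a 1.4-fold lower number from compound 1 to compound 3 (0.13 log units; within the scatter) and is also within the scatter, so all three groups read alike at this position. Nothing measured bears on why these groups read alike. Open, on these data alone, is whether a carboxylic acid, a primary amine or a longer chain on this carbonyl carbon would leave this level. Also open, as far as these compounds go, is whether compounds of this level behave alike on other cell lines.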